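Chlorophenyl for methoxyphenyl on the shared core

This account rests on a few compounds, and the source may have more. Where it says the series, first, only, none or still open, it means among the compounds named here.

Compound 1 `CNC(=O)c1cc(Oc2ccc(NC(=O)c3nccc(-c4ccc(OC)cc4)n3)cc2)ccn1` gives 14200 nM in a functional assay on PC-3 cells (Homo sapiens) for cytotoxicity, read by MTT assay, with a stated time of 72 h (a higher number here means a weaker inhibitor, a lower number a stronger inhibitor), the lowest of the two numbers available; compound 2 `CNC(=O)c1cc(Oc2ccc(NC(=O)c3cc(-c4ccc(OC)cc4)ncn3)cc2F)ccn1` gives 56200 nM in this assay, a higher number beyond the scatter. Compound 3 `CNC(=O)c1cc(Oc2ccc(NC(=O)c3nccc(-c4cccc(Cl)c4)n3)cc2)ccn1` is not yet measured. It differs from compound 1 in one place: 3-chlorophenyl in place of 4-methoxyphenyl on an aromatic carbon. Among the compounds with values here, no measured pair shows this change, so the expected step from compound 1 to compound 3 in this assay is small, likely within the scatter: a 1.4-fold lower number from compound 1 to compound 3 (0.15 log units; within the scatter). Compound 3 is estimated at 10000 nM, in the range 3000 nM to 40000 nM.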

Compound 3, half-maximal inhibitory concentration: 20800 nM
Estimate against measurement, compound 3: 2.1-fold (0.32 log units) below, within the range that was stated.
By their numbers in this assay, from the lowest: compounds 1 and 3 (each within the scatter of the next); then compound 2.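

In this assay, within the data shown here, the step is a 1.5-fold higher number from compound 1 to compound 3 (0.17 log units; within the scatter), the first reading of a change at this position on the shared core. At this level of the assay, 3-chlorophenyl and 4-methoxyphenyl cannot be told apart here, although the hydrogen-bond acceptor counted in 4-methoxyphenyl is absent from 3-chlorophenyl. Nothing measured bears on why the two groups read alike.

From the compounds shown here alone, whether 4-chlorophenyl, or a phenyl carrying an amine or a carboxylic acid, would read differently remains open. So does whether any change at this position gives a step beyond the scatter.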